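From compound 2 to compound 4: losing the methoxy

The source may report more compounds than this note shows. Statements on the series, on what has been measured and on what is new or still open speak of the compounds shown alone.

Measured in an ADME assay on BAEC cells (Bos taurus) for cytotoxicity, read by MTT assay, with a stated time of 2 days; on this read-out lower numbers stand for stronger inhibition and higher numbers for weaker inhibition

Compound 1 `COC1=C(Br)C(=O)[C@]2(C=C1Br)CO2` gives (161000 nM)
Compound 2 `COC1=CC(=O)[C@]2(C=C1Br)CO2` gives (> 22000 nM) as a limit, not a number
Compound 3 `COC1=CC(=O)[C@]2(C=C1)CO2` gives (33000 nM)

Compound 2 has no exact place on this scale. It stands at the limit of > 22000 nM in this assay, at which 1 of the 3 values shown sits, which is a limit and not a number.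

Compound 4 `O=C1C=CC(Br)=C[C@]12CO2` differs from compound 2 in one place: hydrogen in place of methoxy on a double-bonded ring carbon. In plain words, this is hydrogen in place of methoxy on a double-bonded ring carbon.

Going by the values given here, no measured step makes this swap. The two nearest steps, a step that the limit leaves unreadable from compound 1 to compound 2 and a step that the limit leaves unreadable from compound 2 to compound 3, each put hydrogen in place of bromo instead, and the limit hides the size of both. That leaves only the readable values as a guide. Compound 1 reads (161000 nM) and compound 3 reads (33000 nM), so the family sits at high numbers on this read-out. With no step to lean on, no change beyond the usual scatter can be forecast in this assay in either direction, and compound 4 is expected to stay among these high numbers.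

The expected step is a step that the limit leaves unreadable from compound 2 to compound 4 and remains a rough estimate.

For compound 4 the estimated value is 30000 nM with an expected range of 8000 nM to 120000 nM on the same scale.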

Compound 4, half-maximal inhibitory concentration: > 25000 nM
Compound 4: a limit, no number; the forecaster's own chance of this, stated with the estimate: 30%; the middle value does not contradict the limit.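

In this assay, compound 4 gives > 25000 nM, which is a limit and not a number. Compound 2 gives > 22000 nM, also a limit, so no step can be read between compound 2 and compound 4. The compounds shown leave open whether hydrogen in place of methoxy changes the value at all, and in which direction.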